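A few compounds are considered here, and "the series" means these few. Any claim that something is new, unique, unknown or untested is made for them only; others in the source may bear on it.

Compound 1 `FC(F)(F)c1ccc(CSc2nc(Nc3ccccc3Cl)c3ccccc3n2)cc1` carries the 2-chlorophenyl group on the nitrogen of the shared core. In a functional assay on MGC-803 cells (Homo sapiens) for cytotoxicity, read by MTT assay, with a stated time of 72 h (a higher number here means a weaker inhibitor, a lower number a stronger inhibitor), compound 1 reaches only a limit, > 50000 nM, not a number. Compound 2 `FC(F)(F)c1ccc(CSc2nc(Nc3cccc(Cl)c3)c3ccccc3n2)cc1` carries the 3-chlorophenyl group instead, and in this assay compound 2 gives 14600 nM. The change gave an at least 3.4-fold lower number from compound 1 to compound 2 (0.53 log units; beyond the scatter). Among the compounds with values here, compound 2 thus holds the only numerical value among the two measured compounds; the other result sits at the limit of > 50000 nM in this assay, at which 1 of the 2 values shown sits. Compound 3 `FC(F)(F)c1ccc(CSc2nc(Nc3ccc(Cl)cc3)c3ccccc3n2)cc1` differs from compound 2 by 4-chlorophenyl in place of 3-chlorophenyl on a nitrogen on an aromatic ring. Within the data shown here, only the one step bears on this move of the chlorine, and it ran toward a lower number; it does not tell how a further move behaves. Compound 3 is therefore expected near compound 2, with a step of a 1.2-fold lower number from compound 2 to compound 3 (0.09 log units; within the scatter) in this assay, and an estimate of 12000 nM spanning 3500 nM to 45000 nM.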

Compound 3, half-maximal inhibitory concentration: 16800 nM
For compound 3 the middle estimate is 1.4-fold (0.15 log units) below the measured one; low and high end bracket the measured number.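

In this assay, the 3-chlorophenyl and 4-chlorophenyl groups on the nitrogen are not separated: the result is a 1.2-fold higher number from compound 2 to compound 3 (0.06 log units; within the scatter). The earlier compounds shown here set the 2-chlorophenyl group against only one other placement of the chlorine; a second placement now also stands apart from it, with an at least 2.9-fold lower number from compound 1 to compound 3 (0.47 log units; beyond the scatter). Among these three compounds, only the 2-chlorophenyl group stands apart, and compound 1 still gives a limit, not a number: the limit of > 50000 nM in this assay, at which 1 of the 3 values shown sits.

On these data alone, how wide the gap to compound 1 really is remains open, as both steps from it are bounded by that limit. Also open, as far as these compounds go, is whether a 4-methoxyphenyl or a 3-bromophenyl group on the same nitrogen would match compound 2 and compound 3 or depart from them.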